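Compound 3 to compound 4: trifluoromethyl out, piperidin-1-yl in

The source may hold more compounds than are shown below. What is called first, only, known or untested is meant among the compounds shown, and "the series" means these compounds.

Of the compounds shown here, three on the shared core have been measured in an ADME assay for permeability, using PAMPA, with a stated time of 3 h; a lower number here means that the compound crosses the layer more slowly, a higher number that the compound crosses the layer faster: compound 1 `O=C(Nc1ccc([N+](=O)[O-])cc1)c1cc(Cl)ccc1O` gives 12.4 10^-6 cm/s, compound 2 `O=C(Nc1ccc(F)cc1)c1cc(Cl)ccc1O` gives 18.2 10^-6 cm/s and compound 3 `O=C(Nc1ccc(C(F)(F)F)cc1)c1cc(Cl)ccc1O` gives 6.9 10^-6 cm/s. Compound 3 stands clearly apart from only one of the other two. Trifluoromethyl in place of fluoro gives a 2.6-fold lower number from compound 2 to compound 3 (0.42 log units; beyond the scatter), the only measured step beyond the scatter. Trifluoromethyl in place of nitro gives a 1.8-fold lower number from compound 1 to compound 3 (0.25 log units; within the scatter), and fluoro in place of nitro gives a 1.5-fold higher number from compound 1 to compound 2 (0.17 log units; within the scatter).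

Compound 4 `O=C(Nc1ccc(N2CCCCC2)cc1)c1cc(Cl)ccc1O` is not yet measured. It carries piperidin-1-yl in place of trifluoromethyl on an aromatic carbon, para to a large group: piperidin-1-yl in place of trifluoromethyl on an aromatic carbon. Among the compounds with values here, no measured compound carries the entering group, so the three steps above bear on this change by size only, and all of them are modest or smaller. A large step is therefore not expected, and a drift toward compound 1 at 12.4 10^-6 cm/s is the working assumption. The estimated change is a 1.4-fold higher number from compound 3 to compound 4 (0.16 log units; within the scatter), which would not stand out from the scatter. For compound 4 the expected value is 10 10^-6 cm/s, with an estimated range of 4 10^-6 cm/s to 22 10^-6 cm/s.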

Compound 4, apparent permeability: 43.3 10^-6 cm/s
Beside the measured number, compound 4's estimate is 4.3-fold (0.64 log units) below it; the measured number lies above the stated range.
By their numbers in this assay, from the lowest: compounds 3, 1 and 2 (each within the scatter of the next, the first and the last beyond it); then compound 4.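

In this assay, piperidin-1-yl on this aromatic carbon, para to a large group, gives a 6.3-fold higher number from compound 3 to compound 4 (0.80 log units; beyond the scatter), and compound 4 also stands apart from the other two compounds, with a 2.4-fold higher number from compound 2 to compound 4 (0.38 log units; beyond the scatter) and a 3.5-fold higher number from compound 1 to compound 4 (0.54 log units; beyond the scatter). All three steps lie beyond the scatter, so compound 4 has the highest number of the four, and this place on the shared core can hold a group with a six-membered non-aromatic ring and a hydrogen-bond acceptor without a lower number than those of compounds 1, 2 and 3, none of which carries a ring at this place. The compounds shown offer no measurement that bears on the origin of these steps.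

Still open, on these data alone, is whether the higher number goes with the ring nitrogen, the ring carbons or the ring itself, a question that cyclohexyl, morpholin-4-yl or an open-chain dimethylamino group at the same place could help to separate. Also open, as far as these compounds go, is whether piperidin-1-yl would give a similar step on a core without the chloro group or the hydroxyl group of the shared core.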